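Branched hydroxyalkyl thioethers on a shared pyrazolopyrimidine core

The compounds below may be only part of what the source reports. "The series", "measured", "known", "first", "only" and "open" are said of these compounds alone.

Measured in a functional assay on HT cells (Homo sapiens) for antiproliferative activity, read by fluorescence, with a stated time of 72 h; on this read-out higher numbers stand for weaker inhibition of growth and lower numbers for stronger inhibition of growth:
- compound 1 `CCC(O)CSc1nc(NCc2ccc(-c3ccccn3)cc2)c2[nH]nc(C(C)C)c2n1`: 273 nM
- compound 2 `CC(C)c1n[nH]c2c(NCc3ccc(-c4ccccn4)cc3)nc(SC(C)C(C)O)nc12`: 190 nM
- compound 3 `CC(C)c1n[nH]c2c(NCc3ccc(-c4ccccn4)cc3)nc(SC3CCCCC3O)nc12`: 636 nM

Compound 3 gives the highest number of the three. Its nearest neighbour is compound 1, and the step between them is a 2.3-fold higher number from compound 1 to compound 3 (0.37 log units; beyond the scatter); the step from compound 2 is larger, at a 3.3-fold higher number from compound 2 to compound 3 (0.52 log units; beyond the scatter). The two open-chain groups themselves are close, since a 1.4-fold lower number from compound 1 to compound 2 (0.16 log units; within the scatter).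

Compound 4 `CC(C)c1n[nH]c2c(NCc3ccc(-c4ccccn4)cc3)nc(SCC(C)(C)O)nc12` differs from compound 3 only at the sulfur: 2-hydroxy-2-methylpropyl in place of 2-hydroxycyclohexyl on a sulfur. Both steps in which the ring on the sulfur was swapped for an open chain, from compound 1 and from compound 2, bear on this change, and both were modest and beyond the scatter. Compound 4 is therefore expected to show a modest lower number in this assay than compound 3, a step of about a 2.4-fold lower number from compound 3 to compound 4 (0.39 log units; beyond the scatter). The estimate for compound 4 is 260 nM, with a range from 120 nM to 560 nM.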

Compound 4, concentration for 50% growth inhibition: 507 nM
For compound 4 the middle estimate is 2.0-fold (0.29 log units) below the measured one; the measured number falls inside the stated range.
By their numbers in this assay, from the lowest: compounds 2, 1, 4 and 3 (each within the scatter of the next, the first and the last beyond it).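

In this assay, an open chain on the sulfur does not by itself separate a compound from the ring-bearing compound 3: with 2-hydroxy-2-methylpropyl in place of 2-hydroxycyclohexyl, the result is a 1.3-fold lower number from compound 3 to compound 4 (0.10 log units; within the scatter). The open chains also prove not to be interchangeable, since a 1.9-fold higher number from compound 1 to compound 4 (0.27 log units; within the scatter) stays within the scatter, whereas a 2.7-fold higher number from compound 2 to compound 4 (0.43 log units; beyond the scatter) goes beyond it, so the earlier closeness of compound 1 and compound 2 does not extend to every open chain at this position. Nothing beyond these growth-inhibition numbers is available to explain the steps.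

The compounds shown leave open whether the hydroxyl is needed at all on these groups. They also leave open how an amine or a carboxylic acid in its place, or a longer chain on the sulfur, would read in this assay.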